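This account rests on a few compounds, and the source may have more. Where it says the series, first, only, none or still open, it means among the compounds named here.

Measured in a functional assay on NUGC-3 cells (Homo sapiens) for antiproliferative activity, read by sulforhodamine B assay; a higher number here means a weaker inhibitor of growth, a lower number a stronger inhibitor of growth:
- Compound 1 `CC(C)CCCOc1cccc(O)c1C(=O)/C=C/c1ccc(O)cc1`: 3520 nM
- Compound 2 `CC(C)=CCOc1cccc(O)c1C(=O)/C=C/c1ccc(O)cc1`: > 30000 nM (a limit of the assay, not a number)

Compound 2 gives > 30000 nM, which is a limit and not a number. Compound 3 `O=C(/C=C/c1ccc(O)cc1)c1c(O)cccc1OCCC1CCCCC1` has not yet been measured. It differs from compound 2 in one group: cyclohexylmethyl in place of 2-methylprop-1-en-1-yl on a saturated chain carbon bound to an oxygen on an aromatic ring. Cut one bond further out, 3-methylbut-2-en-1-yl gives way to 2-cyclohexylethyl.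

Among the measured compounds shown here, only one measured step bears on this change, and it sits at the same place: an at least 8.5-fold higher number from compound 1 to compound 2 (0.93 log units; beyond the scatter). The step runs in the direction of losing growth inhibition as the 3-methylbut-2-en-1-yl group comes in. That same group leaves on the way to compound 3, which makes a step toward a lower number in this assay the likely outcome, of broadly similar size to the step just given. For the measured compounds named here, this rests on a single step, and the six-membered ring of compound 3 has no measured counterpart, so the range stays wide.

The expected change is an at least 6.0-fold lower number from compound 2 to compound 3 (0.77 log units; beyond the scatter). For compound 3 the estimate is 5000 nM, with an expected range from 1500 nM to 20000 nM.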

Compound 3, concentration for 50% growth inhibition: > 30000 nM
Compound 3 gave a limit, no number; the forecaster's own chance of this, stated with the estimate: 20%; middle value at least 6.0-fold (0.77 log units) from the limit.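

The result shows that the loss of growth inhibition at this position is not confined to the 3-methylbut-2-en-1-yl group of compound 2: a saturated chain ending in a six-membered ring also falls short of compound 1 in this assay. With cyclohexyl in place of isobutyl, the change is an at least 8.5-fold higher number from compound 1 to compound 3 (0.93 log units; beyond the scatter), so among the three compounds shown, only the isopentyl chain of compound 1 gives a measurable value. The step between compound 2 and compound 3 cannot be read, because both compounds stop at the same limit and not at a number: the limit of > 30000 nM in this assay, at which 2 of the 3 values shown sit.

As far as these compounds go, whether compound 2 and compound 3 truly differ in growth inhibition therefore remains unknown, and the double bond and the ring cannot be ranked against each other. From the compounds shown here alone, it also remains open how this position would respond to a shorter chain such as n-butyl, to a phenyl ring at the end of the chain, or to an amine there, and whether any of these would match or improve on compound 1.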